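The compounds below may be only part of what the source reports. "The series", "measured", "known", "first", "only" and "open" are said of these compounds alone.

The measured compounds:
Compound 1 `CCC[C@H]1C[C@@H](O)[C@@H](O)C1` gives > 350000 nM in an ADME assay on S2 cells (Drosophila melanogaster) for cytotoxicity, read by MTT assay; on this read-out higher numbers stand for an effect only at larger amounts of compound and lower numbers for an effect already at smaller amounts; this is a limit of the assay rather than a number.
Compound 2 `O=C(/C=C/[C@H]1C[C@@H](O)[C@@H](O)C1)Oc1ccccc1` gives > 200000 nM in this assay; this too is a limit rather than a number.
Compound 3 `O=C(/C=C/[C@H]1C[C@@H](O)[C@@H](O)C1)NO` gives > 250000 nM in this assay, again a limit rather than a number.

All three compounds share the same core and differ only in the group attached to it. None of them shows a measurable effect within the tested range, so none has a true number to compare. Compound 2 stands at the limit of > 200000 nM in this assay, at which 1 of the 3 values shown sits, and every other value shown is likewise a limit, so no ordering among the three can be drawn.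

Compound 4 `O=C(O)/C=C/[C@H]1C[C@@H](O)[C@@H](O)C1` is the next compound, not yet measured. It differs from compound 2 by hydrogen in place of phenyl on an oxygen next to a carbonyl group; the change sits on an oxygen next to a carbonyl group. Among the measured compounds shown here, since no measured pair gives a numbered step, the expectation rests on the three limits alone: the step from compound 2 to compound 4 is expected to be none beyond the scatter, a step that the limit leaves unreadable from compound 2 to compound 4, with compound 4 most likely also reported only as a limit. For compound 4 the estimate in this assay is 300000 nM, between 100000 nM and 900000 nM.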

Compound 4, half-maximal effective concentration: > 350000 nM
Compound 4: no number, only a limit; the forecaster's own chance of this, stated with the estimate: 85%; middle value at least 1.1-fold (0.06 log units) away from the limit.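

In this assay compound 4 gives > 350000 nM, which is a limit and not a number. The steps to compound 4 from compound 2 and from compound 3 cannot be read, as all three values are limits. The compounds shown leave open whether any of them affects these cells at all, and whether changing the attached group matters.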